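Thiosemicarbazone Variation on a Terpenoid Scaffold: Cytotoxicity Expectation

The source may hold more compounds than are shown below. What is called first, only, known or untested is meant among the compounds shown, and "the series" means these compounds.

Measured compounds:
Compound 1, `CC1=CC[C@@H]([C@@](C)(O)CCCC(C)(C)NC(=S)N/N=C\c2ccccc2)CC1`: 43800 nM
Compound 2, `CC1=CC[C@@H]([C@@](C)(O)CCCC(C)(C)NC(=S)N/N=C\c2ccc(O)cc2)CC1`: 40100 nM

In a functional assay on UACC-62 cells (Homo sapiens) for cytotoxicity, read by sulforhodamine B assay (on this read-out lower numbers stand for stronger inhibition of growth and higher numbers for weaker inhibition of growth), compound 1 gives 43800 nM and compound 2 gives 40100 nM; the two numbers sit within the scatter of each other, so neither can be set above the other. Going by the values given here, the one recorded step, a 1.1-fold lower number from compound 1 to compound 2 (0.04 log units; within the scatter), is the only comparison available. Compound 3, `CC1=CC[C@@H]([C@@](C)(O)CCCC(C)(C)NC(=S)N/N=C\c2ccc(N(C)C)cc2)CC1`, has not yet been measured. It differs from compound 2 by dimethylamino in place of hydroxy on an aromatic carbon. Among the compounds with values here, no measured step trades one substituent for another at this position; the only step bearing on this site, a 1.1-fold lower number from compound 1 to compound 2 (0.04 log units; within the scatter), stayed within the scatter. On that basis the account expects compound 3 to land close to compound 2 in this assay, with any shift, a 1.1-fold lower number from compound 2 to compound 3 (0.06 log units; within the scatter), expected to be no larger than the scatter. The estimate for compound 3 is 35000 nM, with a range from 15000 nM to 80000 nM.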

Compound 3, concentration for total growth inhibition: > 100000 nM
Compound 3: only a limit was reported (the forecaster's own chance of this, stated with the estimate: 5%); middle value at least 2.8-fold (0.45 log units) away from the limit.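

In this assay, this aromatic carbon had looked indifferent while hydroxy in place of hydrogen stayed within the scatter, but it is not indifferent to every group: dimethylamino in place of hydroxy gives an at least 2.4-fold higher number from compound 2 to compound 3 (0.39 log units; beyond the scatter), and dimethylamino in place of hydrogen gives an at least 2.2-fold higher number from compound 1 to compound 3 (0.35 log units; beyond the scatter). The reading for compound 3 is a limit and not a number: the limit of > 100000 nM in this assay, at which 1 of the 3 values shown sits.

Both steps therefore give only a least size, and the lack of any step seen with hydroxy does not extend to dimethylamino at this place.

The compounds shown leave open whether the step belongs to dimethylamino alone or would also appear with a primary amine, a methoxy group or a carboxylic acid on the same carbon. They also leave open whether dimethylamino on another carbon of the ring would give a step of this kind.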